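Benzyl for chlorophenyl on the triazole: a second look

A few compounds are considered here, and "the series" means these few. Any claim that something is new, unique, unknown or untested is made for them only; others in the source may bear on it.

Measured compounds:
Compound 1, `CCCCCc1ccc(C#Cc2c(-c3ccc(CCCCC)cc3)oc3nc(=O)n(Cc4cn(-c5ccc(Cl)cc5)nn4)cc23)cc1` — > 100000 nM (a limit of the assay)
Compound 2, `CCCCCCC#Cc1c(CCCCCC)oc2nc(=O)n(Cc3cn(-c4ccc(Cl)cc4)nn3)cc12` — > 100000 nM (a limit of the assay)
Compound 3, `CCCCCCC#Cc1c(CCCCCC)oc2nc(=O)n(Cc3cn(Cc4ccccc4)nn3)cc12` — 21900 nM

The three compounds were tested in a functional assay on A549 cells (Homo sapiens) for antiproliferative activity, read by MTT assay, with a stated time of 72 h; a higher number here means a weaker inhibitor, a lower number a stronger inhibitor. Compound 1 reached only a limit there, > 100000 nM. Compound 2 likewise gave only a limit, > 100000 nM. Compound 3 gave a number, 21900 nM.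

Compound 2 and compound 3 differ in one place: benzyl in place of 4-chlorophenyl on an aromatic nitrogen. That change produced an at least 4.5-fold lower number from compound 2 to compound 3 (0.65 log units; beyond the scatter). The size of this step can only be set as a lower bound because of the limit of > 100000 nM in this assay, at which 2 of the 3 values shown sit.

Compound 1 and compound 2 are built on different cores; the difference between the two cores is not broken down here.

The unmeasured compound 4, `CCCCCc1ccc(C#Cc2c(-c3ccc(CCCCC)cc3)oc3nc(=O)n(Cc4cn(Cc5ccccc5)nn4)cc23)cc1`, stands to compound 1 as compound 3 stands to compound 2: benzyl in place of 4-chlorophenyl on an aromatic nitrogen. The two place descriptions agree word for word, so this is the same change on a different core.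

Since compound 1 sits at the same limit as compound 2, the starting point is equally uncertain, and the core it is made on differs. Compound 4 is therefore expected to show a step of about an at least 2.5-fold lower number from compound 1 to compound 4 (0.39 log units; beyond the scatter), resting on compound 2 and compound 3 giving an at least 4.5-fold lower number from compound 2 to compound 3 (0.65 log units; beyond the scatter). The estimate for compound 4 is 40000 nM, with a plausible range from 12000 nM to 100000 nM, and a real chance that the assay again reports only a limit.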

Compound 4, half-maximal inhibitory concentration: > 100000 nM
Compound 4 was reported as a limit; the forecaster's own chance of this, stated with the estimate: 35%; at least 2.5-fold (0.39 log units) between middle value and limit.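

In this assay compound 4 gave only a limit, > 100000 nM. For the compounds shown here, compound 1 also sits at a limit, so no step from compound 1 to compound 4 can be read, because both values are limits: the limit of > 100000 nM in this assay, at which 3 of the 4 values shown sit. The compounds shown leave open whether benzyl in place of 4-chlorophenyl lowers the number at all on the core of compound 1, as it does on the core of compound 3.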